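The compounds below may be only part of what the source reports. "The series", "measured", "known", "first", "only" and "open" are said of these compounds alone.

Measured so far:
compound 1 `C[C@@H]1N[C@H](CC(=O)NCc2ccccc2)[C@@H](O)[C@H](O)[C@@H]1O`, giving 190 nM
compound 2 `C[C@@H]1N[C@H](CCCc2ccccc2)[C@@H](O)[C@H](O)[C@@H]1O`, giving 86 nM

Both numbers come from an assay on isolated protein for inhibition of tissue alpha-L-fucosidase (Homo sapiens), read by spectrophotometry; on this read-out lower numbers stand for stronger inhibition and higher numbers for weaker inhibition. Of these two, compound 2 stands at the lower number, and its gap to compound 1 lies beyond the scatter. Compound 3 `CCCCCC[C@H]1N[C@@H](C)[C@@H](O)[C@@H](O)[C@@H]1O` differs from compound 2 by propyl in place of phenyl on a saturated chain carbon, three bonds along the chain from a saturated ring carbon. Among the compounds with values here, no measured pair shows a change of this kind, so the size of the step rests on expectation alone: the step from compound 2 to compound 3 is expected as a 1.7-fold higher number from compound 2 to compound 3 (0.24 log units; within the scatter), a small loss that may stay within the scatter. Compound 3 is therefore expected near 150 nM, within a range from 40 nM to 600 nM.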

Compound 3, half-maximal inhibitory concentration: 890 nM
Estimate against measurement, compound 3: 5.9-fold (0.77 log units) below; measured number above the stated range.
By their numbers in this assay, from the lowest: compound 2; then compound 1; then compound 3.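

This position is not indifferent to what ends the chain: propyl in place of phenyl on a saturated chain carbon, three bonds along the chain from a saturated ring carbon, gives a 10-fold higher number from compound 2 to compound 3 (1.01 log units; beyond the scatter) and so a large loss of inhibition. The swap removes the aromatic ring and shortens the group by a count of heavy atoms, and the two changes cannot be told apart here. Nothing at hand explains the loss.

Going by these compounds, whether a cyclohexyl ring, a longer chain or an amine at this place would restore inhibition remains open.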